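The source may hold more compounds than are shown below. What is called first, only, known or untested is meant among the compounds shown, and "the series" means these compounds.

Compound 3 `COc1ccc(-c2[nH]c3ccc(OC)cc3c2C=C(C#N)C#N)cc1` and compound 1 `COc1ccc2[nH]c(-c3ccccc3)c(C=C(C#N)C#N)c2c1` share one core and differ only by hydrogen in place of methoxy on an aromatic carbon. In a functional assay on A549 cells (Homo sapiens) for inhibition, read by sulforhodamine B assay, with a stated time of 48 h (on this read-out higher numbers stand for weaker inhibition of growth and lower numbers for stronger inhibition of growth), compound 3 gives 3800 nM, while compound 1 gives 7000 nM, so that this change produced a 1.8-fold higher number from compound 3 to compound 1 (0.27 log units; within the scatter). Compound 2 `COc1ccc(-c2[nH]c3ccc(OC)cc3c2/C=C(\C#N)S(=O)(=O)c2ccccc2)cc1` gives 2800 nM in this assay; the difference between the core of compound 2 and the core of compound 3 is not broken down here. Compound 4 `COc1ccc2[nH]c(-c3ccccc3)c(/C=C(\C#N)S(=O)(=O)c3ccccc3)c2c1` has not yet been measured. Among the compounds with values here, it differs from compound 2 by hydrogen in place of methoxy on an aromatic carbon, the same change as the one between compound 3 and compound 1, at the same place. Because the measured step came out as a 1.8-fold higher number from compound 3 to compound 1 (0.27 log units; within the scatter), the step from compound 2 to compound 4 is expected to be of similar size, a 1.8-fold higher number from compound 2 to compound 4 (0.25 log units; within the scatter). Compound 4 is therefore estimated at 5000 nM, with 2500 nM to 10000 nM as the likely range.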

Compound 4, concentration for 50% growth inhibition: 6000 nM
Estimate against measurement, compound 4: 1.2-fold (0.08 log units) below, and the stated range covers the measured number.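

In this assay, going from 4-methoxyphenyl to phenyl on the second core gives a 2.1-fold higher number from compound 2 to compound 4 (0.33 log units; beyond the scatter). Set beside the earlier step, the change carries over from one core to the other at a similar size: the same change on two cores in this assay, a 1.8-fold higher number (0.27 log units; within the scatter) from compound 3 to compound 1 and a 2.1-fold higher number (0.33 log units; beyond the scatter) from compound 2 to compound 4, 1.2-fold (0.07 log units) apart, within the scatter of two such steps This rests on only two pairs of compounds, and one of the two steps lies within the scatter, so it shows agreement on these two cores only; it does not show that the change would behave alike on any other core, nor why it has this size.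

As far as these compounds go, only methoxy and hydrogen appear at this place, so it stays open how a hydroxyl, an amine, a carboxylic acid or a longer chain such as butoxy would read here. Whether the step holds in other cell lines is open too.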